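A Smaller Amide Where Only Limits Are Known So Far

The compounds below may be only part of what the source reports. "The series", "measured", "known", "first", "only" and "open" are said of these compounds alone.

Of the compounds shown here, two with the shared core have been measured in a functional assay on KB cells (Homo sapiens) for inhibition, read by sulforhodamine B assay, with a stated time of 72 h (on this read-out higher numbers stand for weaker inhibition of growth and lower numbers for stronger inhibition of growth), so far. Compound 1 (`CNC(=O)CCc1ccncc1-c1ccc2ccccc2c1`) gives > 10000 nM as its result, which is a limit of the assay and not a number. Compound 2 (`COC1CN(C(=O)/C=C/c2ccncc2-c2ccc3ccccc3c2)C1`) gives > 10000 nM as its result, and this too is only a limit. Compound 2 therefore has no exact place on the scale, and the whole record so far reads as the limit of > 10000 nM in this assay, at which 2 of the 2 values shown sit, and nothing more.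

Compound 3 (`CN(C)C(=O)/C=C/c1ccncc1-c1ccc2ccccc2c1`) keeps the core and the carbonyl but carries dimethylamino in place of 3-methoxyazetidin-1-yl on a carbonyl carbon. For the measured compounds named here, no measured step shows what this exchange does in this assay and no number exists to start from, so no change beyond the scatter is expected, in either direction. The expected step that the limit leaves unreadable from compound 2 to compound 3 is accordingly a small one, resting on the limit that compound 2 shows at > 10000 nM as its result. For compound 3 the estimated value is 14000 nM (range 6000 nM to 30000 nM), and another limit is the likeliest report.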

Compound 3, concentration for 50% growth inhibition: 7760 nM
Beside the measured number, compound 3's estimate is 1.8-fold (0.26 log units) above it; the range from low to high includes it.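

For the compounds shown here, with compound 3 the record gains its only exact number in this assay: compound 3 gives 7760 nM, which shows that a compound with dimethylamino on this carbonyl carbon can be placed on the scale. Exchanging 3-methoxyazetidin-1-yl for dimethylamino gives an at least 1.2-fold lower number from compound 2 to compound 3 (0.11 log units; that floor lies within the scatter), and 2-(dimethylcarbamoyl)ethenyl in place of 2-(methylcarbamoyl)ethyl on an aromatic carbon gives an at least 1.2-fold lower number from compound 1 to compound 3 (0.11 log units; that floor lies within the scatter), so these records alone do not establish a change beyond the scatter, though the true size of either step may be larger. The rest of the record remains a limit of the assay and not a number: the limit of > 10000 nM in this assay, at which 2 of the 3 values shown sit.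

From the compounds shown here alone, the true size of these two steps remains unknown, and the comparison between the two compounds that sit at the limit cannot be read. Also open, going by these compounds, is whether diethylamino, morpholin-4-yl or a longer chain on the same carbonyl carbon, or a carboxylic acid in place of the amide, would move the result further from that of compound 3 in this assay.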